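The source may hold more compounds than are shown below. What is called first, only, known or untested is meant among the compounds shown, and "the series" means these compounds.

Two compounds of the series carry numbers in a functional assay on cells (Cancer cell lines, Homo sapiens) for inhibition; a lower number here means a stronger inhibitor of growth, a higher number a weaker inhibitor of growth. Compound 1 `Cc1cc(-c2nc3sc(C)cn3c2/C=N/NC(=N)N)c(C)s1` gives 8320 nM in this assay. Among the measured compounds shown here, compound 2 `Cc1cn2c(/C=N/Nc3ccccn3)c(-c3ccc(Cl)c([N+](=O)[O-])c3)nc2s1` gives 7760 nM in this assay; the gap to compound 1 lies within the scatter, so the two cannot be separated, and compound 1 stands level with the only other number known. Compound 3 `Cc1cn2c(/C=N/NC(=N)N)c(-c3ccsc3)nc2s1` has not yet been measured in this assay. It differs from compound 1 in one place: thiophen-3-yl in place of 2,5-dimethylthiophen-3-yl on an aromatic carbon. For the measured compounds named here, no step between measured compounds shows what the loss of the methyl groups from this ring does, so the expectation rests on compound 1 alone and the direction is open. The step expected from compound 1 to compound 3 is a 1.2-fold higher number from compound 1 to compound 3 (0.08 log units; within the scatter), small and not clearly beyond the scatter. Compound 3 is therefore estimated at 10000 nM in this assay, within a range from 3000 nM to 35000 nM.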

Compound 3, concentration for 50% growth inhibition: 6920 nM
Beside the measured number, compound 3's estimate is 1.4-fold (0.16 log units) above it; the measured number falls inside the stated range.
By their numbers in this assay, from the lowest: compounds 3, 2 and 1 (each within the scatter of the next).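

In this assay, among the compounds shown here, the first step at this position reads a 1.2-fold lower number from compound 1 to compound 3 (0.08 log units; within the scatter), so thiophen-3-yl and 2,5-dimethylthiophen-3-yl cannot be separated on this evidence. For this one pair, the dimethyl substitution on the thiophene ring is therefore not needed to hold the number at the level of compound 1, although a single pair shows nothing about other groups at this position. No supporting data are available to explain this result.

Going by these compounds, what a carboxylic acid or a primary amine on the thiophene ring would do remains open, and so does the effect of a longer chain such as n-butyl there. It is also unknown whether a phenyl ring in place of the thiophene would give a number beyond the scatter of compound 3.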